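Trading a chlorine-carrying ring for thiophen-3-yl

This account rests on a few compounds, and the source may have more. Where it says the series, first, only, none or still open, it means among the compounds named here.

In a functional assay on ileum (Cavia porcellus) for inhibition (on this read-out lower numbers stand for stronger inhibition and higher numbers for weaker inhibition), compound 1 (`COC(=O)C1=C(C)NC(C)=C(C(=O)OC)C1c1c(-c2cccnc2)nc2sc(C)cn12`) gives 16000 nM and compound 2 (`COC(=O)C1=C(C)NC(C)=C(C(=O)OC)C1c1c(-c2c(Cl)csc2Cl)nc2sc(C)cn12`) gives 3230 nM as the lower of the two numbers. Compound 3 (`COC(=O)C1=C(C)NC(C)=C(C(=O)OC)C1c1c(-c2ccsc2)nc2sc(C)cn12`) keeps the shared core and differs from compound 2 in one group, with a group of 5 heavy atoms (4 carbon, 1 sulfur; one five-membered aromatic ring with 1 hetero atom) in place of a group of 7 heavy atoms (4 carbon, 1 sulfur, 2 chlorine; one five-membered aromatic ring with 1 hetero atom), on an aromatic carbon as the change, and the group that enters is thiophen-3-yl. Among the measured compounds shown here, one measured step bears on this place: a 5.0-fold lower number from compound 1 to compound 2 (0.69 log units; beyond the scatter) when a six-membered aromatic ring gave way to the chlorine-carrying group. That step changed ring type and chlorine together, and the data cannot separate the two. Compound 3 keeps a five-membered aromatic ring but has no chlorine, so a smaller step towards a higher number is expected in this assay than that earlier one. The estimated step is a 2.2-fold higher number from compound 2 to compound 3 (0.34 log units; beyond the scatter) in size. For compound 3 the estimated value is 7000 nM with a likely range from 1800 nM to 20000 nM in this measurement.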

Compound 3, half-maximal inhibitory concentration: 3520 nM
Compound 3: the middle estimate sits 2.0-fold (0.30 log units) above what was measured, within the range that was stated.
By their numbers in this assay, from the lowest: compounds 2 and 3 (each within the scatter of the next); then compound 1.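

In this assay, compound 2 and compound 3 cannot be told apart, with a 1.1-fold higher number from compound 2 to compound 3 (0.04 log units; within the scatter), so the two chlorine atoms on the five-membered ring make no difference that this measurement can detect. Thiophen-3-yl in place of pyridin-3-yl gives a 4.5-fold lower number from compound 1 to compound 3 (0.66 log units; beyond the scatter), a step of much the same size as a 5.0-fold lower number from compound 1 to compound 2 (0.69 log units; beyond the scatter). This separates what the earlier step left mixed: among these three compounds, the difference goes with the exchange of the six-membered ring for the sulfur-containing five-membered ring, and not with the chlorine atoms.

The compounds shown leave open how a plain phenyl ring, a furan-3-yl or a thiophen-2-yl would compare at this position. The data also give no reason for the difference between the pyridin-3-yl and thiophen-3-yl compounds.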